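Carboxymethyl in place of carboxy on the tetramethylene chain

The compounds below may be only part of what the source reports. "The series", "measured", "known", "first", "only" and "open" are said of these compounds alone.

Of the compounds shown here, two have been measured in a functional assay for antagonist activity at thromboxane A2 receptor (Homo sapiens); on this read-out lower numbers stand for stronger inhibition and higher numbers for weaker inhibition. Compound 1 `O=C(O)c1ccc2c(c1)CC(CCNS(=O)(=O)c1ccc(Cl)cc1)C2` gives 7760 nM. Compound 2 `O=C(O)c1ccc2c(c1)CC(CCCCNS(=O)(=O)c1ccc(Cl)cc1)C2` gives 100000 nM, the highest of the two numbers and well beyond the scatter from compound 1. Compound 3 `O=C(O)Cc1ccc2c(c1)CC(CCCCNS(=O)(=O)c1ccc(Cl)cc1)C2` keeps the four-carbon chain of compound 2 and differs only in carboxymethyl in place of carboxy on an aromatic carbon. Within the data shown here, no measured pair shows such a change, so the step from compound 2 to compound 3 is expected to be small in this assay and to fall within the scatter, in no certain direction. For compound 3 the estimated value in this assay is 60000 nM, with a range from 15000 nM to 200000 nM, a step of a 1.7-fold lower number from compound 2 to compound 3 (0.22 log units; within the scatter) expected from compound 2.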

Compound 3, half-maximal inhibitory concentration: > 100000 nM
Compound 3: no number, only a limit; the forecaster's own chance of this, stated with the estimate: 35%; middle value at least 1.6-fold (0.22 log units) from the limit.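

On the chain of compound 2, carboxymethyl in place of carboxy on an aromatic carbon gives a number no lower from compound 2 to compound 3 (the limit leaves the size open) in this assay, so this change brings back no readable inhibition at this position. Compound 3 carries a limit and not a number, so the size of the step cannot be read: the limit of > 100000 nM in this assay, at which 1 of the 3 values shown sits.

From the compounds shown here alone, whether carboxymethyl behaves the same way on the shorter chain of compound 1 stays open. Also open, going by these compounds, is whether an amide or a tetrazole on this aromatic carbon would give a readable number.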